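Adding a hydroxy to compound 2

The compounds below may be only part of what the source reports. "The series", "measured", "known", "first", "only" and "open" are said of these compounds alone.

Measured compounds:
Compound 1 `O=S(=O)(Nc1cccc2cc(O)[nH]c12)c1ccc(Cl)cc1`: 1.1 ug/mL
Compound 2 `O=[N+]([O-])c1ccc(S(=O)(=O)Nc2cccc3cc[nH]c23)cc1`: 15 ug/mL

In a functional assay on KB cells (Homo sapiens) for antiproliferative activity, read by colorimetric assay and MTT assay (on this read-out higher numbers stand for weaker inhibition and lower numbers for stronger inhibition), compound 2 holds the higher of the two numbers at 15 ug/mL, and compound 1 gives 1.1 ug/mL. The gap between these two compounds lies beyond the usual scatter. Compound 3 `O=[N+]([O-])c1ccc(S(=O)(=O)Nc2cccc3cc(O)[nH]c23)cc1` has hydroxy in place of hydrogen on an aromatic carbon of the five-membered aromatic ring, next to the ring nitrogen (hydroxy in place of hydrogen on an aromatic carbon). Within the data shown here, no measured pair isolates this change. Compound 1 carries the same hydroxy and gives 1.1 ug/mL, though it differs from compound 3 elsewhere, so a lower number is expected. The expected step, toward stronger inhibition and beyond the scatter, is estimated as a 6.0-fold lower number from compound 2 to compound 3 (0.78 log units; beyond the scatter). For compound 3 the estimated value is 2.5 ug/mL, with an expected range of 0.6 ug/mL to 10 ug/mL.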

Compound 3, half-maximal inhibitory concentration: > 100 ug/mL
Compound 3 ended at the assay's limit; the forecaster's own chance of this, stated with the estimate: 5%; middle value at least 40-fold (1.60 log units) away from the limit.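

In this assay the value of compound 3 is a limit and not a number: the limit of > 100 ug/mL in this assay, at which 1 of the 3 values shown sits. On the nitro compound, hydroxy in place of hydrogen on an aromatic carbon brings an at least 6.6-fold higher number from compound 2 to compound 3 (0.82 log units; beyond the scatter) and so moves toward weaker inhibition, not stronger. With the hydroxy kept, nitro in place of chloro on an aromatic carbon brings an at least 90-fold higher number from compound 1 to compound 3 (1.95 log units; beyond the scatter) and so shows that the outcome at the hydroxy compounds turns on that second group. The compounds shown leave open what the hydroxy does with chloro present, as no partner without it stands here. They also leave open whether an amine or a methoxy in the same place would follow the hydroxy.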